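This account rests on a few compounds, and the source may have more. Where it says the series, first, only, none or still open, it means among the compounds named here.

Three members of the series have been examined in an ADME assay on HFF cells (Homo sapiens) for cytotoxicity, with a stated time of 8 days (on this read-out lower numbers stand for higher toxicity in this test and higher numbers for lower toxicity in this test), so far, and none gave a numerical result. Compound 1 `Nc1nc(OCC(F)(F)F)c2ncn(/C=C3/CC3(CO)CO)c2n1` reports only a limit of > 300000 nM. Compound 2 `CCCNc1nc(N)nc2c1ncn2/C=C1/CC1(CO)CO` reports a limit of > 300000 nM as well. Compound 3 `Nc1nc(NC2CCCC2)c2ncn(/C=C3/CC3(CO)CO)c2n1`, the starting point of the step followed here, likewise reports a limit of > 300000 nM. On the numbers shown compound 3 therefore stands at the same limit as the other two, (the limit of > 300000 nM in this assay, at which 3 of the 3 values shown sit), and no order among the three can be read. For the same reason the three steps between measured compounds, a step that the two limits leave unreadable from compound 1 to compound 2, a step that the two limits leave unreadable from compound 1 to compound 3 and a step that the two limits leave unreadable from compound 2 to compound 3, are all of unreadable size.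

Compound 4 `Nc1nc(SC2CCCC2)c2ncn(/C=C3/CC3(CO)CO)c2n1` is the untested member. It differs from compound 3 by cyclopentylsulfanyl in place of cyclopentylamino on an aromatic carbon. The step most similar in kind, a step that the two limits leave unreadable from compound 2 to compound 3, exchanges the group carried on the nitrogen while keeping the nitrogen itself, whereas here the linking atom changes; neither it nor the other two steps yields a readable size to build on. In this assay compound 4 is therefore expected to remain at or close to the limit, with an expected step of a number no higher from compound 3 to compound 4 (the limit leaves the size open). The estimate for compound 4 is 300000 nM, expected to lie between 100000 nM and 1000000 nM.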

Compound 4, half-maximal cytotoxic concentration: > 300000 nM
Compound 4 gave a limit, no number (the forecaster's own chance of this, stated with the estimate: 75%); the middle value lies on the limit itself.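

Compound 4 also gives only a limit in this assay, so no step from compound 1, compound 2 or compound 3 to compound 4 can be read: the limit of > 300000 nM in this assay, at which 4 of the 4 values shown sit.

The compounds shown leave open whether any of the four differ from one another in this assay, and at what concentration, if any, cytotoxicity appears.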